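Triazole aryl replacement in a cytotoxicity series

A few compounds are considered here, and "the series" means these few. Any claim that something is new, unique, unknown or untested is made for them only; others in the source may bear on it.

Compound 1 `C/C(=C\CC/C(C)=C/CC[C@@H]1[C@@]2(C)CCC(=O)C(C)(C)[C@H]2CC[C@@]1(C)O)CC/C=C(\C)C(=O)OCc1cn(-c2ccccc2C)nn1` is examined in an ADME assay on L132 cells (Homo sapiens) for cytotoxicity, read by MTT assay, with a stated time of 48 h; a higher number here means a weaker inhibitor, a lower number a stronger inhibitor. For compound 1 the result is a limit of the assay, > 150000 nM. Compound 2 `C/C(=C\CC/C(C)=C/CC[C@@H]1[C@@]2(C)CCC(=O)C(C)(C)[C@H]2CC[C@@]1(C)O)CC/C=C(\C)C(=O)OCc1cn(-c2ccccc2C(F)(F)F)nn1` carries trifluoromethyl in place of methyl on an aromatic carbon; for compound 2 the value is likewise a limit, > 150000 nM. Compound 3 `C/C(=C\CC/C(C)=C/CC[C@@H]1[C@@]2(C)CCC(=O)C(C)(C)[C@H]2CC[C@@]1(C)O)CC/C=C(\C)C(=O)OCc1cn(-c2ccc(F)c(Cl)c2)nn1` gives, again only as a limit, > 150000 nM. The steps a step that the two limits leave unreadable from compound 1 to compound 2, a step that the two limits leave unreadable from compound 1 to compound 3 and a step that the two limits leave unreadable from compound 2 to compound 3 therefore carry no readable size; all three values share (the limit of > 150000 nM in this assay, at which 3 of the 3 values shown sit). Compound 4 `C/C(=C\CC/C(C)=C/CC[C@@H]1[C@@]2(C)CCC(=O)C(C)(C)[C@H]2CC[C@@]1(C)O)CC/C=C(\C)C(=O)OCc1cn(-c2ccc(F)cc2)nn1` differs from compound 1 by 4-fluorophenyl in place of 2-methylphenyl on an aromatic nitrogen. Among the compounds with values here, no measured step resolves this change, so nothing beyond the scatter is anticipated. For compound 4 the expected step is a step that the limit leaves unreadable from compound 1 to compound 4. Compound 4 is estimated at 200000 nM, within 100000 nM to 500000 nM, most likely reported as a further limit.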

Compound 4, half-maximal inhibitory concentration: > 150000 nM
Compound 4: only a limit was reported; the forecaster's own chance of this, stated with the estimate: 85%; the middle value is on the limit's open side.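

Within the data shown here, no step from compound 1, compound 2 or compound 3 to compound 4 can be read, because all these values are limits: the limit of > 150000 nM in this assay, at which 4 of the 4 values shown sit. Going by these compounds, whether any aryl group on the aromatic nitrogen changes the half-maximal inhibitory concentration remains open.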